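This account rests on a few compounds, and the source may have more. Where it says the series, first, only, none or still open, it means among the compounds named here.

Working notes on the series. Three compounds have numbers in a functional assay on the whole organism (Ehrlich cells, Mus musculus) for antiproliferative activity, with a stated time of 24 h, at a dose of 0.2 mmol/kg by the intraperitoneal route; on this read-out higher numbers stand for more inhibition at the one dose given (going by the name of the read-out) and lower numbers for less inhibition. Compound 1 `Nc1ccccc1NC(=O)CCCNCC(=O)Nc1cccc([N+](=O)[O-])c1` gives 40.6%. Compound 3 `COc1ccc(NC(=O)CNCCCC(=O)Nc2ccccc2N)cc1` gives 63.8%. Compound 2 `Nc1ccccc1NC(=O)c1ccc(NCC(=O)Nc2ccc([N+](=O)[O-])cc2)cc1` gives 83.3%, the highest of the three; compound 3 is nearest and compound 1 furthest, both gaps beyond the scatter. Going by the values given here, the single measured step between compounds differing in one place is a number 23.2 percentage points higher from compound 1 to compound 3 (beyond the scatter), in which 4-methoxyphenyl replaced 3-nitrophenyl on an amide-type nitrogen.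

Compound 4 `Nc1ccccc1NC(=O)c1ccc(NCC(=O)Nc2ccc(Cl)cc2)cc1` differs from compound 2 in one place: chloro in place of nitro on an aromatic carbon. Among the compounds with values here, no measured pair shows this exact exchange on the shared core. Within the data shown here, the only step that touches a nitro-bearing ring is the modest upward one from compound 1 to compound 3, but there the whole phenyl pattern changed, not merely the nitro group, so it bears on the present case only loosely. With compound 2 already at the top of the set, a move of either sign is possible; the expected step is a number 11.3 percentage points lower from compound 2 to compound 4 (beyond the scatter), judged not clearly beyond the scatter. Compound 4 is therefore estimated at 72% in this assay, with a range from 52% to 88%.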

Compound 4, a percentage reported as inhibition, in the whole organism at one dose (the size of the read-out at that dose, not a potency): 79.4%
Beside the measured number, compound 4's estimate is 7.4 percentage points below it; the range from low to high includes it.
By their numbers in this assay, from the lowest: compound 1; then compound 3; then compounds 4 and 2 (each within the scatter of the next).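

In this assay, chloro in place of nitro on an aromatic carbon, para to a large group, gives a number 3.9 percentage points lower from compound 2 to compound 4 (within the scatter), so this read-out does not separate the two groups at this position on the shared core. Going by these compounds alone, this is the first exchange confined to the nitro group itself: 3 heavy atoms with 2 hydrogen-bond acceptors give way to 1 heavy atom with 0 hydrogen-bond acceptors, and the reading stays within the scatter, so a nitro group is not needed here for a high reading at the one dose given. No measurement at hand offers an explanation for this result.

Going by these compounds, whether an amine, a carboxylic acid or a methoxy group at this same position would also read within the scatter of compound 2 remains open, as does whether the same exchange would behave alike on the core of compound 1. With one dose and one time point, the compounds shown also leave open whether compound 2 and compound 4 would stay inseparable at other doses.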